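The source may report more compounds than this note shows. Statements on the series, on what has been measured and on what is new or still open speak of the compounds shown alone.

Measured compounds:
- compound 1, `Cc1cccc(-n2nc(-c3ccccc3)nc2CNc2ccc(C(=O)NO)cc2)c1`: 66%
- compound 2, `O=C(NO)c1ccc(NCc2nc(-c3ccccc3)nn2-c2ccc(C(F)(F)F)cc2)cc1`: 38.9%
- compound 3, `O=C(NO)c1ccc(NCc2nc(-c3ccccc3)nn2-c2ccc(Cl)cc2)cc1`: 55.4%

In an assay on Sf9 cells for inhibition of protein deacetylase HDAC6 (Homo sapiens), read by fluorescence, with a stated time of 40 min, tested at 100 nM (on this read-out higher numbers stand for more inhibition at the one concentration tested (going by the name of the read-out) and lower numbers for less inhibition), compound 3 stands second highest of the three numbers. The nearest of the others is compound 1, reached by the step of a number 10.6 percentage points lower from compound 1 to compound 3 (beyond the scatter); the furthest is compound 2, reached by the step of a number 16.5 percentage points higher from compound 2 to compound 3 (beyond the scatter). The step from compound 1 to compound 2, a number 27.1 percentage points lower from compound 1 to compound 2 (beyond the scatter), rounds out the picture.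

Compound 4, `O=C(NO)c1ccc(NCc2nc(-c3ccccc3)nn2-c2ccccc2)cc1`, is the next member of the series, and it differs from compound 3 only at the aromatic ring on the nitrogen: hydrogen in place of chloro on an aromatic carbon.

Within the data shown here, no measured pair shows exactly this change. The step that bears on it most directly is a number 16.5 percentage points higher from compound 2 to compound 3 (beyond the scatter), which altered the same position of the same ring, and the two steps from compound 1 show that swapping the whole ring on the nitrogen moves the number by a modest amount in either direction. None of them is large. The expectation is therefore a small move, within or barely beyond the scatter, with no firm direction; if anything the three numbers point gently upward when that position carries less.

Compound 4 is expected to give 60%, in the range 44% to 76%, which means an estimated step of a number 4.6 percentage points higher from compound 3 to compound 4 (within the scatter).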

Compound 4, a percentage reported as inhibition, at one concentration (the size of the read-out at that concentration, not a potency): 72.6%
Compound 4: the middle estimate sits 12.6 percentage points below what was measured, within the range that was stated.
By their numbers in this assay, from the lowest: compound 2; then compound 3; then compounds 1 and 4 (each within the scatter of the next).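

In this assay, among these compounds, the phenyl ring of compound 4 gives the series its unsubstituted reference point, which the earlier compounds lacked: a number 17.2 percentage points higher from compound 3 to compound 4 (beyond the scatter) and a number 33.7 percentage points higher from compound 2 to compound 4 (beyond the scatter). Both chloro and trifluoromethyl on the aromatic carbon para to a large group therefore stand below hydrogen, so the earlier comparison between those two groups was a comparison between two lower values, and the trifluoromethyl compound lies further from hydrogen. Compound 1 goes against any reading that every substituent on this ring lowers the number, since its 3-methylphenyl ring cannot be separated from the phenyl ring of compound 4: a number 6.6 percentage points higher from compound 1 to compound 4 (within the scatter). No measurement offered here explains why these groups differ.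

What stays open is whether the lower numbers hold for para substituents generally, as only chloro and trifluoromethyl are shown there, and a methoxy group, a fluoro group or an amine on that carbon could fall anywhere relative to hydrogen. Going by these compounds, it is also open whether chloro or trifluoromethyl would match the methyl of compound 1 if placed where that methyl sits in the 3-methylphenyl ring.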